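Pentyl to cyclobutyl on the nitrogen-bound chain carbon

The compounds below may be only part of what the source reports. "The series", "measured", "known", "first", "only" and "open" are said of these compounds alone.

Of the compounds shown here, two sharing one core have been tested in a functional assay on MCF7 cells (Homo sapiens) for cytotoxicity; on this read-out higher numbers stand for an effect only at larger amounts of compound and lower numbers for an effect already at smaller amounts. Compound 1 `COc1cc(Cc2nc3c(N)ncnc3n2CCCO)cc(OC)c1OC` gives 92700000 nM. Compound 2 `CCCCCCn1c(Cc2cc(OC)c(OC)c(OC)c2)nc2c(N)nc(F)nc21` gives 112000000 nM, and the two numbers sit within the scatter of each other, so neither can be called different from the other. Compound 3 `COc1cc(Cc2nc3c(N)nc(F)nc3n2CC2CCC2)cc(OC)c1OC` has not yet been measured; it differs from compound 2 by cyclobutyl in place of pentyl on a saturated chain carbon bound to an aromatic nitrogen. Among the compounds with values here, with no measured step of this kind to lean on, the expected step from compound 2 to compound 3 is a 1.1-fold lower number from compound 2 to compound 3 (0.05 log units; within the scatter), that is, none beyond the scatter. Compound 3 is therefore expected to give about 100000000 nM, within a range from 30000000 nM to 300000000 nM.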

Compound 3, half-maximal effective concentration: 109000000 nM
Beside the measured number, compound 3's estimate is 1.1-fold (0.04 log units) below it, within the range that was stated.
By their numbers in this assay, from the lowest: compounds 1, 3 and 2 (each within the scatter of the next).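

In this assay, within the data shown here, the first measured step at this position is a 1.0-fold lower number from compound 2 to compound 3 (0.01 log units; within the scatter) when cyclobutyl takes the place of pentyl on a saturated chain carbon bound to an aromatic nitrogen. Closing the open chain into a four-membered ring of carbon and losing one heavy atom therefore leaves the read-out within the scatter. No supporting measurement is available to explain this result.

As far as these compounds go, it remains open whether a carboxylic acid or a phenyl ring on this chain would shift the number. A much longer chain, such as decyl, is equally untested here.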